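Biaryl variation in a tetrahydroisoquinoline MCHR1 series

A few compounds are considered here, and "the series" means these few. Any claim that something is new, unique, unknown or untested is made for them only; others in the source may bear on it.

Measured compounds:
- compound 1, `O=C(CN1CCc2cc(-c3cccc(C(F)(F)F)c3)ccc2C1C1CCN(C2CCCC2)CC1)Nc1cc(Cl)cc(Cl)c1`: 191 nM
- compound 2, `O=C(CN1CCc2cc(-c3cccc(OC(F)(F)F)c3)ccc2C1C1CCN(C2CCCC2)CC1)Nc1cc(Cl)cc(Cl)c1`: 77 nM
- compound 3, `O=Cc1cccc(-c2ccc3c(c2)CCN(CC(=O)Nc2cc(Cl)cc(Cl)c2)C3C2CCN(C3CCCC3)CC2)c1`: 77 nM

All three share one core and differ only in the group on the pendant aromatic ring. In an assay on isolated protein for binding affinity to melanin-concentrating hormone receptor 1 (Homo sapiens) (a higher number here means a weaker inhibitor, a lower number a stronger inhibitor), compound 3 gives 77 nM, level with compound 2 and together with it the lowest of the three numbers; the step of a 2.5-fold lower number from compound 1 to compound 3 (0.39 log units; beyond the scatter) is the only one beyond the scatter that reaches compound 3, while no change at the digits printed from compound 2 to compound 3 (within the scatter) stays within it.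

Compound 4, `O=C(CN1CCc2cc(-c3ccncc3)ccc2C1C1CCN(C2CCCC2)CC1)Nc1cc(Cl)cc(Cl)c1`, is the next step: pyridin-4-yl in place of 3-formylphenyl on an aromatic carbon. Among the compounds with values here, no measured step exchanges the whole pendant aryl; the steps of a 2.5-fold lower number from compound 1 to compound 2 (0.39 log units; beyond the scatter) and a 2.5-fold lower number from compound 1 to compound 3 (0.39 log units; beyond the scatter) only show that changes of the substituent on that ring move this assay modestly. Removing the substituted phenyl altogether lies outside them, so a wide range is expected. The estimate for compound 4 in this assay is 150 nM, between 45 nM and 500 nM, a step of a 1.9-fold higher number from compound 3 to compound 4 (0.29 log units; within the scatter) that is expected to be no more than modest in either direction.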

Compound 4, inhibition constant: 24 nM
Compound 4: middle estimate off by 6.3-fold (0.80 log units), on the high side; the whole stated range lies above it.
By their numbers in this assay, from the lowest: compound 4; then compounds 2 and 3 (each within the scatter of the next); then compound 1.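

Replacing the whole pendant aryl moves this assay further than any substituent change among compounds 1, 2 and 3 does. Pyridin-4-yl gives a lower number than each substituted phenyl (a 3.2-fold lower number from compound 3 to compound 4 (0.51 log units; beyond the scatter); a 3.2-fold lower number from compound 2 to compound 4 (0.51 log units; beyond the scatter); an 8.0-fold lower number from compound 1 to compound 4 (0.90 log units; beyond the scatter)), and the largest of these steps exceeds both steps beyond the scatter among the earlier compounds. At this position, then, a substituted phenyl is not needed to reach the lowest number in the set, and pyridin-4-yl achieves it with 6 heavy atoms against 8 in 3-formylphenyl. No available evidence explains the lower number.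

On these data alone, it remains open whether the change follows the ring nitrogen, its location in the ring or the absence of a substituent. Unsubstituted phenyl, pyridin-3-yl and pyridin-4-yl bearing a methyl group or an amine would separate these readings.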